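Extending the nitrogen substituent in a fused bicyclic series

This account rests on a few compounds, and the source may have more. Where it says the series, first, only, none or still open, it means among the compounds named here.

Compound 1 `CCc1nc2c(-c3ccc(Cl)cc3Cl)ccnc2n1[C@@H](CC)C1CC1` gives 0.4 nM in an assay for binding affinity to Corticotropin releasing factor receptor (Rattus norvegicus) (a lower number here means a stronger inhibitor, a higher number a weaker inhibitor), the lowest of the three numbers shown. Compound 3 `CCc1nc2c(-c3ccc(C(F)(F)F)cc3Cl)ncnc2n1C(C1CC1)C1CC1` gives 1.8 nM in this assay, a higher number beyond the scatter, and compound 2 `CCC(CCOC)n1c(C2CC2)nc2c(-c3ccc(C(F)(F)F)cc3Cl)ccnc21` gives 20.8 nM, the highest number of the three, also beyond the scatter. Compound 4 `CCc1nc2c(-c3ccc(Cl)cc3Cl)ccnc2n1C(CCOC)C1CCC1` differs from compound 1 by 1-cyclobutyl-3-methoxypropyl in place of 1-cyclopropylpropyl on an aromatic nitrogen. Going by the values given here, no single-point step between measured compounds covers this change, so the expectation rests on compound 1 alone. A modest loss is expected in this assay, giving an expected step of a 3.8-fold higher number from compound 1 to compound 4 (0.57 log units; beyond the scatter) that may remain near the scatter. Compound 4 is therefore estimated at 1.5 nM, within a range from 0.4 nM to 6 nM.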

Compound 4, inhibition constant: 2.4 nM
The estimate for compound 4 lay 1.6-fold (0.20 log units) below the measured number, and the stated range covers the measured number.
By their numbers in this assay, from the lowest: compound 1; then compounds 3 and 4 (each within the scatter of the next); then compound 2.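

In this assay, 1-cyclobutyl-3-methoxypropyl in place of 1-cyclopropylpropyl on the aromatic nitrogen gives a 6.0-fold higher number from compound 1 to compound 4 (0.78 log units; beyond the scatter) as a modest step. This position therefore accepts a substituent with more heavy atoms, a four-membered ring and a hydrogen-bond acceptor, while compound 4 keeps a low nanomolar number. No available evidence accounts for the size of this step.

The ring and the chain change together, so their separate contributions remain unresolved. From the compounds shown here alone, it also remains open how an amine or a hydroxyl group in place of the methoxy group would fare at this position.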